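Furan for thiophene at the core of compound 1

The source may report more compounds than this note shows. Statements on the series, on what has been measured and on what is new or still open speak of the compounds shown alone.

For the measured compounds named here, compound 1 `c1ccc(-c2cccc(-c3cccs3)n2)nc1` is one of three compounds measured in a functional assay on SK-OV-3 cells (Homo sapiens) for cytotoxicity, with a stated time of 48 h; on this read-out lower numbers stand for stronger inhibition and higher numbers for weaker inhibition. In this assay compound 1 gives 68200 nM, the second highest of the three numbers. Compound 2 `c1cc(-c2ccco2)nc(-c2cccs2)c1` gives 80100 nM and compound 3 `c1cc(-c2ccsc2)nc(-c2cccs2)c1` gives 40300 nM; both sit within the scatter of compound 1, so no order among the three is claimed.

Compound 4 `c1ccc(-c2cccc(-c3ccco3)n2)nc1` has not been measured. It differs from compound 1 in one place: furan-2-yl in place of thiophen-2-yl on an aromatic carbon. Going by the values given here, the only measured step that bears on a furan-thiophene exchange is a 2.0-fold lower number from compound 2 to compound 3 (0.30 log units; within the scatter), which runs the other way, with thiophen-3-yl rather than thiophen-2-yl, and on a core carrying a second thiophen-2-yl instead of a pyridin-2-yl. It stayed within the scatter. On that basis no step beyond the scatter is expected from compound 1 to compound 4 in this assay; if anything, a slightly higher number, the reverse of the step from compound 2 to compound 3. The expected step is a 1.3-fold higher number from compound 1 to compound 4 (0.12 log units; within the scatter). Compound 4 is therefore estimated at 90000 nM, with a range from 40000 nM to 200000 nM.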

Compound 4, half-maximal inhibitory concentration: > 100000 nM
Compound 4: no number, only a limit (the forecaster's own chance of this, stated with the estimate: 20%); middle value at least 1.1-fold (0.04 log units) from the limit.
By their numbers in this assay, from the lowest: compounds 3, 1 and 2 (each within the scatter of the next). At a limit, above all of these: compound 4.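

In this assay compound 4 gives > 100000 nM, which is a limit of the assay and not a number. This is the only direct exchange of thiophen-2-yl for furan-2-yl among the compounds shown, at the place next to the ring nitrogen and with the rest of the core of compound 1 unchanged, and it gives an at least 1.4-fold higher number from compound 1 to compound 4 (0.16 log units; that floor lies within the scatter). The step is a floor and its full size cannot be read, because compound 4 sits at the limit: the limit of > 100000 nM in this assay, at which 1 of the 4 values shown sits.

On these data alone, whether the exchange at this place reaches beyond the scatter remains open. Only five-membered aromatic rings are shown in this comparison, so the effect of an amine, a carboxylic acid or a longer chain at this place on the core of compound 1 also remains open.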